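Adding a methyl to the aromatic ring of compound 1

This account rests on a few compounds, and the source may have more. Where it says the series, first, only, none or still open, it means among the compounds named here.

Compound 1, `CC1CC/C(=N\Nc2ccccc2)c2ncc(/C=C/C(=O)O)c(=O)n21`, is tested in a functional assay on the whole organism with Rattus norvegicus as the target (a lower number here means that less compound is needed, a higher number that more compound is needed for the effect), where compound 1 gives 0.27 umol/kg. Of the two numbers shown, it is the higher, and compound 2 sits nearest. Compound 2, `C[C@H]1CC/C(=N\Nc2ccccc2)c2ncc(/C=C/C(=O)O)c(=O)n21`, gives 0.15 umol/kg in this assay. Compound 3, `C[C@@H]1CC/C(=N\Nc2ccccc2)c2ncc(/C=C/C(=O)O)c(=O)n21`, reaches only > 100 umol/kg in this assay, which is a limit of the assay and not a number. The step of a 1.8-fold lower number from compound 1 to compound 2 (0.26 log units; within the scatter) is within the scatter; this pair is set apart by the fact that one of compounds 1 and 2 is drawn with a defined configuration and the other without, at the place where they differ. The steps of an at least 370-fold higher number from compound 1 to compound 3 (2.56 log units; beyond the scatter) and an at least 660-fold higher number from compound 2 to compound 3 (2.82 log units; beyond the scatter) are large, and the second of them rests on (the fact that compounds 2 and 3 differ only in the configuration as drawn), while the first is tied to the fact that one of compounds 1 and 3 is drawn with a defined configuration and the other without, at the place where they differ.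

Compound 4, `Cc1nc2n(c(=O)c1/C=C/C(=O)O)C(C)CC/C2=N\Nc1ccccc1`, differs from compound 1 in one place: methyl in place of hydrogen on an aromatic carbon. Within the data shown here, none of the measured steps changes a group on an aromatic carbon; all three concern only the configuration at a saturated ring carbon, so none of them bears directly on this change. With no comparison of that kind available, the expected step is a 1.1-fold higher number from compound 1 to compound 4 (0.05 log units; within the scatter), that is, none beyond the scatter. Compound 4 in this assay is estimated at 0.3 umol/kg, with a range from 0.08 umol/kg to 1.5 umol/kg.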

Compound 4, dose for 50% inhibition: 0.29 umol/kg
The estimate for compound 4 lay 1.0-fold (0.01 log units) above the measured number; the range from low to high includes it.
By their numbers in this assay, from the lowest: compounds 2, 1 and 4 (each within the scatter of the next). At a limit, above all of these: compound 3.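

In this assay, methyl in place of hydrogen on an aromatic carbon gives a 1.1-fold higher number from compound 1 to compound 4 (0.03 log units; within the scatter) and so this place, next to the ring nitrogen and ortho to a 2-carboxyethenyl group, takes one added carbon with no change that can be told from the scatter. The earlier compounds shown here differed only in the configuration at a saturated ring carbon, so they showed how much that place matters but said nothing about the aromatic ring, which this pair now does for one small group. Nothing measured here gives a reason why the number stays within the scatter with the methyl in place.

As far as these compounds go, compound 4 is drawn without a configuration at the saturated ring carbon, so it remains open whether its two mirror-image forms would separate as widely as compounds 2 and 3 do. From the compounds shown here alone, it also remains open whether a longer chain, a methoxy group or an amine on the same aromatic carbon would stay within the scatter of compound 1 as the methyl does.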